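The source may report more compounds than this note shows. Statements on the series, on what has been measured and on what is new or still open speak of the compounds shown alone.

In a physicochemical assay for solubility, read by HPLC, in phosphate buffer, with a stated time of 16 h, at pH 6.8 (on this read-out higher numbers stand for higher solubility and lower numbers for lower solubility), compound 1 (`C[C@H](NC(=O)Cn1nnc2ccccc2c1=O)c1ccc(Cl)cc1`) gives 1900 nM and compound 2 (`C[C@H](NC(=O)Cn1nnc2ccccc2c1=O)c1ccc(Br)cc1`) gives 900 nM while compound 3 (`Cc1ccc([C@H](C)NC(=O)Cn2nnc3ccccc3c2=O)cn1`) stands highest of the three at 9800 nM in this small set. Compound 4 (`Cc1ccc([C@H](C)NC(=O)Cn2nnc3ccccc3c2=O)c(C)c1`) has not been measured. Its difference from compound 3 is 2,4-dimethylphenyl in place of 6-methylpyridin-3-yl on a saturated chain carbon bound to an amide-type nitrogen and a saturated chain carbon and in words it is 2,4-dimethylphenyl in place of 6-methylpyridin-3-yl on a saturated chain carbon bound to an amide-type nitrogen and a saturated chain carbon. Within the data shown here, two measured steps bear on this exchange, as both end at compound 3 and start from a ring of carbon only: a 5.2-fold higher number from compound 1 to compound 3 (0.71 log units; beyond the scatter) is modest and an 11-fold higher number from compound 2 to compound 3 (1.04 log units; beyond the scatter) is large. The step of a 2.1-fold lower number from compound 1 to compound 2 (0.32 log units; beyond the scatter) shows that the carbon-only partners themselves differ, so the reverse exchange is not fixed tightly. A modest to large fall is therefore expected in this assay on leaving compound 3. The expected step is a 6.5-fold lower number from compound 3 to compound 4 (0.82 log units; beyond the scatter) and it remains an estimate. Compound 4 is estimated at 1500 nM with 500 nM to 4500 nM as the expected range.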

Compound 4, solubility: 2700 nM
Estimate against measurement, compound 4: 1.8-fold (0.26 log units) below, within the range that was stated.
By their numbers in this assay, from the lowest: compound 2; then compounds 1 and 4 (each within the scatter of the next); then compound 3.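

In this assay compound 3 stays the highest of the four against a third carbon-only ring at this saturated chain carbon, with a 3.6-fold lower number from compound 3 to compound 4 (0.56 log units; beyond the scatter) as the new step. The carbon-only partners do not read alike, as a 1.4-fold higher number from compound 1 to compound 4 (0.15 log units; within the scatter) leaves 2,4-dimethylphenyl level with 4-chlorophenyl, while a 3.0-fold higher number from compound 2 to compound 4 (0.48 log units; beyond the scatter) separates it from 4-bromophenyl. No measurement in hand explains these steps.

On these data alone, the exchange of 6-methylpyridin-3-yl for 2,4-dimethylphenyl changes both the ring nitrogen and the methyl groups, so the share of each in the step remains open. Also open, as far as these compounds go, is how a phenyl ring without substituents, or a ring bearing an amine or a carboxylic acid, would read at this place.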